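This account rests on a few compounds, and the source may have more. Where it says the series, first, only, none or still open, it means among the compounds named here.

Measured so far:
compound 1 `Nc1nc(-c2cccc(CO)c2)nc2sc(-c3ccccc3)nc12` — 3.7 nM
compound 2 `COc1cccc(-c2nc(N)c3nc(-c4ccccc4)sc3n2)c1` — 35.6 nM

In an assay on CHO cells for displacement of a labelled ligand from adenosine receptor A3 (Homo sapiens), read by scintillation counting, with a stated time of 3 h (on this read-out higher numbers stand for weaker inhibition and lower numbers for stronger inhibition), compound 2 stands at the highest of the two numbers, the weaker binder of the pair. Its nearest neighbour is compound 1, and that step, a 9.6-fold higher number from compound 1 to compound 2 (0.98 log units; beyond the scatter), came with methoxy in place of hydroxymethyl on an aromatic carbon. Compound 3 `Nc1nc(-c2cccc(O)c2)nc2sc(-c3ccccc3)nc12` is not yet measured; it differs from compound 2 by hydrogen in place of methyl on an oxygen on an aromatic ring, that is, methoxy to hydroxy, 3-methoxyphenyl to 3-hydroxyphenyl. Among the compounds with values here, no measured step matches this change exactly. Within the data shown here, the only step at this part of the molecule is the one from compound 1 to compound 2, which shows that a group other than methoxy at this place gave a clearly lower number. A modest drop is therefore expected, roughly a 4.5-fold lower number from compound 2 to compound 3 (0.65 log units; beyond the scatter), though the analogy is loose. Compound 3 is estimated at 8 nM, with a plausible range of 2 nM to 40 nM.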

Compound 3, inhibition constant: 190 nM
Estimate against measurement, compound 3: 24-fold (1.38 log units) below, and the stated range ends below it.
By their numbers in this assay, from the lowest: compound 1; then compound 2; then compound 3.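

In this assay, the change from methoxy to hydroxy moves the number up, not down, with a 5.3-fold higher number from compound 2 to compound 3 (0.73 log units; beyond the scatter), and hydroxy in place of hydroxymethyl gives a 51-fold higher number from compound 1 to compound 3 (1.71 log units; beyond the scatter). So an oxygen-bearing group at this place does not by itself give a low number: among the three groups shown, hydroxymethyl gives the lowest number, methoxy the next and hydroxy the highest, with every step beyond the scatter. Nothing measured here explains this order.

As far as these compounds go, it remains open whether a longer chain ending in hydroxy, such as hydroxyethyl, would match or improve on hydroxymethyl, and how an amine or a carboxylic acid at this place would compare. The three compounds also cannot show whether this order would hold with these groups on another carbon of the ring.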